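The source may report more compounds than this note shows. Statements on the series, on what has been measured and on what is new or still open speak of the compounds shown alone.

Three compounds have readings in a physicochemical assay for solubility, read by HPLC, measured as kinetic solubility, with a stated time of 15 min; a higher number here means a more soluble compound, a lower number a less soluble compound. Compound 1 `O=[N+]([O-])c1cn2c(n1)OC[C@H](OCc1ccc(-c3ccc(C(F)(F)F)cc3Cl)cn1)C2` gives 1 ug/mL and compound 2 `CC1(COc2ccc(OC(F)(F)F)cc2)CCn2cc([N+](=O)[O-])nc2S1(=O)=O` gives 1.1 ug/mL, two values within the scatter of each other. Compound 3 `O=[N+]([O-])c1cn2c(n1)OC[C@H](OCC#Cc1ccc(-c3ccc(OC(F)(F)F)cc3)cn1)C2` reads < 0.1 ug/mL, which is a limit of the assay and not a number. Compound 4 `O=[N+]([O-])c1cn2c(n1)OC[C@H](OCC#Cc1ccc(-c3ccc(C(F)(F)F)cc3)cn1)C2` differs from compound 3 in one place, with trifluoromethyl in place of trifluoromethoxy on an aromatic carbon, para to a large group (trifluoromethyl in place of trifluoromethoxy on an aromatic carbon). Going by the values given here, no measured pair isolates this change, and the limit of compound 3 at < 0.1 ug/mL is the only anchor. The estimate is a small a number no lower from compound 3 to compound 4 (the limit leaves the size open), with nothing expected beyond the scatter. For compound 4 the estimated value is 0.1 ug/mL, with an expected range of 0.05 ug/mL to 0.4 ug/mL.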

Compound 4, solubility: 0.68 ug/mL
Beside the measured number, compound 4's estimate is 6.8-fold (0.83 log units) below it; the measured number lies above the stated range.
By their numbers in this assay, from the lowest: compounds 4, 1 and 2 (each within the scatter of the next). At a limit, below all of these: compound 3.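

Trifluoromethyl in place of trifluoromethoxy on an aromatic carbon, para to a large group, gives the first one-place step in this assay, with an at least 6.8-fold higher number from compound 3 to compound 4 (0.83 log units; beyond the scatter). This position therefore responds to a change of this small a size, by a step beyond the scatter. Compound 3 reads < 0.1 ug/mL, a limit and not a number, which leaves the full size of the step unfixed: the limit of < 0.1 ug/mL in this assay, at which 1 of the 4 values shown sits.

From the compounds shown here alone, a single pair sets no pattern, and whether the same change gives a like step on the core of compound 2 stays open. Going by these compounds, how an amine or a carboxylic acid at this position would read in this assay also stays open.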